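A few compounds are considered here, and "the series" means these few. Any claim that something is new, unique, unknown or untested is made for them only; others in the source may bear on it.

Compound 1 `COC1=C(C)C(=O)/C(=C(O)/C=C/c2ccc(Br)cc2)C(=O)C1(C)C` is one of two compounds that share the same core and differ only in the aromatic ring at the end of the chain. In a functional assay on PC-3 cells (Homo sapiens) for cytotoxicity (on this read-out lower numbers stand for an effect already at smaller amounts and higher numbers for an effect only at larger amounts of compound), compound 1 gives 17.7 ug/mL. Compound 2 `COC1=C(C)C(=O)/C(=C(O)/C=C/c2ccc(OC)cc2)C(=O)C1(C)C` gives 18.2 ug/mL in this assay, so the two numbers sit within the usual scatter of each other, and the step of a 1.0-fold higher number from compound 1 to compound 2 (0.01 log units; within the scatter) shows no real movement.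

Compound 3 `COC1=C(C)C(=O)/C(=C(O)/C=C/c2ccccc2C)C(=O)C1(C)C` has not been measured. The change from compound 1 is 2-methylphenyl in place of 4-bromophenyl on a double-bonded chain carbon bound to a double-bonded chain carbon. Within the data shown here, the only measured step that bears on this is the one from compound 1 to compound 2, where exchanging one group on that same aromatic ring for another left the number essentially unchanged. A swap of groups on this ring is therefore expected to produce at most a step within the scatter, in no particular direction, that is a 1.0-fold higher number from compound 1 to compound 3 (0.01 log units; within the scatter). Compound 3 is thus estimated at 18 ug/mL in this assay, with a likely range from 9 ug/mL to 36 ug/mL.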

Compound 3, concentration for half-maximal effect: 9 ug/mL
For compound 3 the middle estimate is 2.0-fold (0.30 log units) above the measured one; the measured number falls inside the stated range.
By their numbers in this assay, from the lowest: compounds 3, 1 and 2 (each within the scatter of the next, the first and the last beyond it).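

In this assay the aromatic ring at the end of the chain is no longer a place where swaps leave the number unmoved: with 2-methylphenyl in place of 4-methoxyphenyl there is a 2.0-fold lower number from compound 2 to compound 3 (0.31 log units; beyond the scatter), a modest step and the first beyond the scatter at this position. With 2-methylphenyl in place of 4-bromophenyl there is a 2.0-fold lower number from compound 1 to compound 3 (0.29 log units; within the scatter), which stays within the scatter, so the effect of this group can be read only as small and only against one of the two earlier compounds. Nothing available explains this small step.

On these data alone, whether an amine or a carboxylic acid on this ring would shift the number further remains open. So does the outcome of replacing the ring with a longer chain of carbon atoms, or of making the same swaps on a different core.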